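From 3-fluorophenyl to 4-bromophenyl on the chain

A few compounds are considered here, and "the series" means these few. Any claim that something is new, unique, unknown or untested is made for them only; others in the source may bear on it.

Going by the values given here, in a functional assay on SW-620 cells (Homo sapiens) for cytotoxicity, read by MTT assay, with stated times of 4 h and 72 h, tested at 2 uM (on this read-out higher numbers stand for weaker inhibition and lower numbers for stronger inhibition), compound 3 (`Cc1cc(Nc2ccc(C(=O)/C=C/c3cccc(F)c3)cc2)n2nc(SCc3nc4ccccc4[nH]3)nc2n1`) gives 590 nM and so sits in the middle of the three numbers known. Compound 1 (`Cc1cc(Nc2ccc(C(=O)/C=C/c3ccc(OC(F)(F)F)cc3)cc2)n2nc(SCc3nc4ccccc4[nH]3)nc2n1`) lies lower with 220 nM and compound 2 (`Cc1cc(Nc2ccc(C(=O)/C=C/c3ccc(C(F)(F)F)cc3)cc2)n2nc(SCc3nc4ccccc4[nH]3)nc2n1`) lies highest with 1850 nM on this scale.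

Compound 4 (`Cc1cc(Nc2ccc(C(=O)/C=C/c3ccc(Br)cc3)cc2)n2nc(SCc3nc4ccccc4[nH]3)nc2n1`) keeps the shared core and differs from compound 3 in one place (4-bromophenyl in place of 3-fluorophenyl on a double-bonded chain carbon bound to a double-bonded chain carbon) where 4-bromophenyl stands in place of 3-fluorophenyl on a double-bonded chain carbon bound to a double-bonded chain carbon.

Among the compounds with values here, three measured steps bear on this exchange, all modest and all beyond the scatter. Replacing 4-(trifluoromethoxy)phenyl with 3-fluorophenyl gave a 2.7-fold higher number from compound 1 to compound 3 (0.43 log units; beyond the scatter) and replacing 4-(trifluoromethyl)phenyl with 3-fluorophenyl gave a 3.1-fold lower number from compound 2 to compound 3 (0.50 log units; beyond the scatter) in the opposite direction. The change from trifluoromethoxy to trifluoromethyl alone gave an 8.4-fold higher number from compound 1 to compound 2 (0.92 log units; beyond the scatter) and shows how far two groups named at the same place can part. Within the data shown here, no compound carrying bromine has been measured, and the neighbours of compound 3 fall on both sides of it, so no direction is favoured in this assay and no shift beyond the scatter is expected. The expected change is a 1.0-fold higher number from compound 3 to compound 4 (0.01 log units; within the scatter) with a wide margin on either side. The estimate for compound 4 is 600 nM with an expected range from 200 nM to 1800 nM as its limits.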

Compound 4, half-maximal inhibitory concentration: 290 nM
Beside the measured number, compound 4's estimate is 2.1-fold (0.32 log units) above it; low and high end bracket the measured number.
By their numbers in this assay, from the lowest: compounds 1 and 4 (each within the scatter of the next); then compound 3; then compound 2.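

In this assay, 4-bromophenyl in place of 3-fluorophenyl on a double-bonded chain carbon bound to a double-bonded chain carbon gave a 2.0-fold lower number from compound 3 to compound 4 (0.31 log units; beyond the scatter), the first measured step from compound 3 to a bromine-bearing ring. Read on the aromatic carbon, bromo in place of trifluoromethyl gave a 6.4-fold lower number from compound 2 to compound 4 (0.80 log units; beyond the scatter), while bromo in place of trifluoromethoxy gave a 1.3-fold higher number from compound 1 to compound 4 (0.12 log units; within the scatter), so this position separates trifluoromethyl from the other two groups, and bromo and trifluoromethoxy cannot be told apart on this read-out. Nothing available explains why these groups part in this way.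

Because 3-fluorophenyl and 4-bromophenyl differ in both the halogen and the number in the name, the compounds shown cannot say how much of the step from 3-fluorophenyl to 4-bromophenyl belongs to either difference. They also leave open how an amine or a carboxylic acid in place of bromo on the aromatic carbon would read in this assay, since every group shown there carries a halogen.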